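The compounds below may be only part of what the source reports. "The series", "measured", "known", "first", "only" and "open" are said of these compounds alone.

Of the compounds shown here, three sharing one core have been measured. Compound 1 `CN(C)C(=O)c1cc2cnc(Nc3ccc(C(=O)NCCCCN=C=S)cc3)nc2n1C1CCCC1` gives 30.2% in a functional assay on A549 cells (Homo sapiens) for inhibition, read by CCK-8 assay, with a stated time of 72 h, tested at 1 uM; a lower number here means a weaker effect, a higher number a stronger effect of the compound at the concentration tested. Compound 2 `CN(C)C(=O)c1cc2cnc(Nc3ccc(C(=O)NCCCCCN=C=S)cc3)nc2n1C1CCCC1` gives 29.3% in this assay, and compound 3 `CN(C)C(=O)c1cc2cnc(Nc3ccc(NC(=O)CCCN=C=S)cc3)nc2n1C1CCCC1` gives 56.1%. Compound 3 therefore stands highest of the three, its step over compound 1 being a number 25.9 percentage points higher from compound 1 to compound 3 (beyond the scatter) and its step over compound 2 being a number 26.8 percentage points higher from compound 2 to compound 3 (beyond the scatter), both beyond the scatter. Compound 4 `CN(C)C(=O)c1cc2cnc(Nc3ccc(NC(=O)CCCCN=C=S)cc3)nc2n1C1CCCC1` has not yet been measured. It differs from compound 3 in one place: a group of 4 heavy atoms (2 carbon, 1 nitrogen, 1 sulfur; no ring) in place of a group of 3 heavy atoms (1 carbon, 1 nitrogen, 1 sulfur; no ring), on a saturated chain carbon, three bonds along the chain from a carbonyl carbon. Among the compounds with values here, the step from compound 1 to compound 2 is the only measured change of the same kind, a longer chain ending in the same group, and it gave a number 0.9 percentage points lower from compound 1 to compound 2 (within the scatter), a change within the scatter. On that basis, lengthening the chain in compound 4 is expected to leave the inhibition close to that of compound 3, with a step of about a number 3.1 percentage points lower from compound 3 to compound 4 (within the scatter). The estimate for compound 4 is 53%, expected to lie between 40% and 66%.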

Compound 4, a percentage reported as inhibition, at one concentration (the size of the read-out at that concentration, not a potency): 38.2%
For compound 4 the middle estimate is 14.8 percentage points above the measured one, and the stated range ends above it.
By their numbers in this assay, from the lowest: compounds 2, 1 and 4 (each within the scatter of the next); then compound 3.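

In this assay, a longer chain ending in the same group is not a neutral change at this position, on a saturated chain carbon three bonds along the chain from a carbonyl carbon: it gave a number 17.9 percentage points lower from compound 3 to compound 4 (beyond the scatter). The effect of chain length therefore depends on the core that carries it, mattering on one core and not on the other: the same change on two cores in this assay, a number 0.9 percentage points lower (within the scatter) from compound 1 to compound 2 and a number 17.9 percentage points lower (beyond the scatter) from compound 3 to compound 4, 17 percentage points apart, beyond the scatter of two such steps.
With the longer chain, compound 4 no longer stands apart from the two earlier compounds, giving a number 8.9 percentage points higher from compound 2 to compound 4 (within the scatter) and a number 8 percentage points higher from compound 1 to compound 4 (within the scatter).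

From the compounds shown here alone, whether a still longer chain on the core of compound 3 would lower the number further remains open, as does the effect of an amine or a carboxylic acid in place of the chain's end group. Going by these compounds, each reading comes from one concentration, so it shows only a stronger or weaker effect at that concentration, and how these compounds would compare at other concentrations remains open.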